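The source may hold more compounds than are shown below. What is called first, only, known or untested is meant among the compounds shown, and "the series" means these compounds.

Of the compounds shown here, two have been tested in a functional assay on SW480 cells (Homo sapiens) for antiproliferative activity, read by MTT assay, with a stated time of 48 h; on this read-out higher numbers stand for weaker inhibition and lower numbers for stronger inhibition. Compound 1 (`CCC(CCO)n1cnc2c(Cl)ncnc21`) is reported there only as a limit, > 50000 nM. Among the measured compounds shown here, compound 2 (`CCCCC(CCO)n1cnc2c(Cl)nc(F)nc21`) gives 13200 nM, the only actual number available so far.

Compound 3 (`CCCCC(CCO)n1cnc2c(Cl)ncnc21`) has not yet been measured in this assay. It departs from compound 2 by a single change, hydrogen in place of fluoro on an aromatic carbon, between two ring nitrogen atoms and meta to a chloro group. For the measured compounds named here, no measured pair in this small set isolates such a change, so the judgement of its size rests on no direct precedent. The expected step, a 1.5-fold higher number from compound 2 to compound 3 (0.18 log units; within the scatter), is a small one toward weaker inhibition in this assay, and it is not expected to clear the usual scatter of the measurement. The estimated value for compound 3 is 20000 nM, with an expected range from 8000 nM to 50000 nM.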

Compound 3, half-maximal inhibitory concentration: > 50000 nM
Compound 3 ended at the assay's limit (the forecaster's own chance of this, stated with the estimate: 20%); at least 2.5-fold (0.39 log units) between middle value and limit.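

In this assay, among the compounds shown here, hydrogen in place of fluoro on the aromatic carbon between two ring nitrogen atoms gives an at least 3.7-fold higher number from compound 2 to compound 3 (0.57 log units; beyond the scatter) and is the first readable step in the set, showing that this position responds to a single-atom change. Compound 3 keeps the same side chain as compound 2, so among the compounds shown the fluoro group is the one difference that separates a measurable value from a limit. The step from compound 1 to compound 3, ethyl in place of hydrogen on a saturated chain carbon, cannot be read, as both compounds stand at the limit, and so the added ethyl shows no measurable gain while this position carries hydrogen.

As far as these compounds go, whether a chloro group, an amine or a methoxy group on this same aromatic carbon would give stronger or weaker inhibition than fluoro remains open, as does the effect of ethyl in place of hydrogen on the chain when fluoro is present. The full size of the fluoro step also stays unknown because the value for compound 3 is only a limit: the limit of > 50000 nM in this assay, at which 2 of the 3 values shown sit.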